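Changing the Amide Substituent: From Cyclopropyl to a Hydroxylated Chain

The source may hold more compounds than are shown below. What is called first, only, known or untested is meant among the compounds shown, and "the series" means these compounds.

Three compounds that share one core and differ only in the group attached to the amide nitrogen have been tested in a functional assay on HEK293 cells for positive allosteric modulation of metabotropic glutamate receptor 5 (Rattus norvegicus), read by fluorescence and calcium flux; on this read-out higher numbers stand for larger maximal responses and lower numbers for smaller maximal responses. Compound 1 `CC(C)[C@H](C)NC(=O)c1ccc(C#Cc2cccc(F)c2)cn1` gives 66.7% in this assay. Compound 2 `CC(C)(C)CNC(=O)c1ccc(C#Cc2cccc(F)c2)cn1` gives 63.9%, and compound 3 `O=C(NCC1CC1)c1ccc(C#Cc2cccc(F)c2)cn1` gives 61.4%. All three numbers lie close together: the step of a number 2.8 percentage points lower from compound 1 to compound 2 (within the scatter) and the step of a number 5.3 percentage points lower from compound 1 to compound 3 (within the scatter) are both within the scatter, as is the step of a number 2.5 percentage points lower from compound 2 to compound 3 (within the scatter). Compound 3 therefore sits among the others rather than apart from them.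

Compound 4 `CC(C)(O)CCNC(=O)c1ccc(C#Cc2cccc(F)c2)cn1` differs from compound 3 in one place: 2-hydroxy-2-methylpropyl in place of cyclopropyl on a saturated chain carbon bound to an amide-type nitrogen. Within the data shown here, the step that bears most directly on this change is the one from compound 2 to compound 3, since it also swaps the group on the saturated chain carbon bound to the amide nitrogen, and that step stayed within the scatter. Among the measured compounds shown here, no measured step introduces a hydroxyl group, so there is nothing to show a shift in either direction. The expected step is therefore a number 1.6 percentage points higher from compound 3 to compound 4 (within the scatter), meaning no change beyond the scatter. Compound 4 is expected to give 63% in this assay, with a range from 50% to 76%.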

Compound 4, largest response reached (reported as efficacy), in percent of the reference or control that the assay uses: 61.9%
Compound 4: middle estimate off by 1.1 percentage points, on the high side; the range from low to high includes it.
By their numbers in this assay, from the lowest: compounds 3, 4, 2 and 1 (each within the scatter of the next).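

Placed on a saturated chain carbon bound to an amide-type nitrogen, 2-hydroxy-2-methylpropyl stays within the scatter in this assay of all three earlier groups: cyclopropyl (a number 0.5 percentage points higher from compound 3 to compound 4 (within the scatter)), tert-butyl (a number 2 percentage points lower from compound 2 to compound 4 (within the scatter)) and, read one bond further out as 3-hydroxy-3-methylbutyl, 1,2-dimethylpropyl (a number 4.8 percentage points lower from compound 1 to compound 4 (within the scatter)). Among the compounds shown, this amide substituent had so far carried only carbon and hydrogen, and compound 4 shows that a chain with a hydrogen-bond donor and a hydrogen-bond acceptor also keeps the maximal response within the scatter of theirs. No measured evidence accounts for this result.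

The compounds shown leave open whether an amine or a carboxylic acid in place of the hydroxyl group would also stay within the scatter. A methyl ether, or a longer chain carrying the hydroxyl group, also remains an open case.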